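Replacing a Small Ring with a Fluorinated Aromatic Ring

The compounds below may be only part of what the source reports. "The series", "measured", "known", "first", "only" and "open" are said of these compounds alone.

Compound 1 `CN1C(=O)C(C2CC2)N(C)c2nc(Nc3ccc(S(N)(=O)=O)cc3)ncc21` is the starting point. Going by the values given here, in an assay on Sf9 cells for inhibition of serine/threonine-protein kinase 4 (Homo sapiens), read by luminescence and ADP-Glo, with a stated time of 1 h, in the presence of a further agent that is not named here (on this read-out lower numbers stand for stronger inhibition and higher numbers for weaker inhibition), compound 1 gives 136 nM, the second highest of the three numbers measured so far. Compound 2 `CN1C(=O)C(CC2CC2)N(C)c2nc(Nc3ccc(S(N)(=O)=O)cc3)ncc21` gives 211 nM and compound 3 `CC(C)CC1C(=O)N(C)c2cnc(Nc3ccc(S(N)(=O)=O)cc3)nc2N1C` gives 77 nM. The step of a 1.6-fold higher number from compound 1 to compound 2 (0.19 log units; within the scatter) and the step of a 1.8-fold lower number from compound 1 to compound 3 (0.25 log units; within the scatter) both stay within the scatter, while the step of a 2.7-fold lower number from compound 2 to compound 3 (0.44 log units; beyond the scatter) is modest but beyond it.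

The new compound 4 `CN1C(=O)C(c2ccc(F)cc2)N(C)c2nc(Nc3ccc(S(N)(=O)=O)cc3)ncc21` differs from compound 1 in one place: 4-fluorophenyl in place of cyclopropyl on a saturated ring carbon. Among the compounds with values here, every measured step exchanges one group for another at that same ring carbon, and none moves the number far; an aromatic ring entering there, however, has no direct counterpart among them, so the measured steps give only a loose guide. The step expected here is a 1.1-fold higher number from compound 1 to compound 4 (0.04 log units; within the scatter), with no confident direction. For compound 4 the estimated value is 150 nM, expected to fall between 50 nM and 450 nM.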

Compound 4, half-maximal inhibitory concentration: 1770 nM
Estimate against measurement, compound 4: 12-fold (1.07 log units) below, outside the stated range (above it).
By their numbers in this assay, from the lowest: compounds 3, 1 and 2 (each within the scatter of the next, the first and the last beyond it); then compound 4.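

At this saturated ring carbon, the cyclopropyl, cyclopropylmethyl and isobutyl groups had moved the number only a little in this assay, which gave no sign that the position has a limit; 4-fluorophenyl reveals one, with a 13-fold higher number from compound 1 to compound 4 (1.11 log units; beyond the scatter) and a large loss of inhibition. The loss also holds against the other two groups, with a 23-fold higher number from compound 3 to compound 4 (1.36 log units; beyond the scatter) and an 8.4-fold higher number from compound 2 to compound 4 (0.92 log units; beyond the scatter), so compound 4 is the weakest inhibitor of the four. No measurement shown here bears on why the number rises.

On these data alone, it remains open whether the aromatic ring or its fluorine accounts for the change, a question that a plain phenyl ring on the same carbon would address. Also open, as far as these compounds go, is whether a benzyl group, which sets the aromatic ring one carbon further out, would be treated the same way.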